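Working notes on compounds 1 to 3

This account rests on a few compounds, and the source may have more. Where it says the series, first, only, none or still open, it means among the compounds named here.

Compound 1, `c1cc([C@H]2CC[C@]3(CC2)OOC2(O3)C3CC4CC(C3)CC2C4)ccc1OCCCNC1CCOCC1`, gives 10 mL.min-1.g-1 in an ADME assay on microsomes from liver (Homo sapiens) for metabolic stability, read by LC-MS, tested at 1 uM; a higher number here means faster removal of the compound, a lower number slower removal.
Compound 2, `OC1(COc2ccc([C@H]3CC[C@]4(CC3)OOC3(O4)C4CC5CC(C4)CC3C5)cc2)CCNCC1`, gives 16 mL.min-1.g-1 in this assay.

Within the data shown here, compound 1 sits at one end of the two numbers, but the only measured step, a 1.6-fold higher number from compound 1 to compound 2 (0.20 log units; within the scatter), lies within the scatter, so the two compounds cannot be told apart in this assay.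

Compound 3, `NCCCCOc1ccc([C@H]2CC[C@]3(CC2)OOC2(O3)C3CC4CC(C3)CC2C4)cc1`, is not yet measured. The change from compound 1 is aminomethyl in place of (oxan-4-yl)amino on a saturated chain carbon, three bonds along the chain from an oxygen on an aromatic ring. Among the measured compounds shown here, the one measured step alters the same saturated chain carbon, yet it exchanges a different group and stays within the scatter; no step removes the (oxan-4-yl)amino group on its own. The expectation therefore rests on compound 1 alone and its step to compound 2, and amounts to no step beyond the scatter, a 1.1-fold lower number from compound 1 to compound 3 (0.05 log units; within the scatter). For compound 3 the estimate in this assay is 9 mL.min-1.g-1, expected between 4 mL.min-1.g-1 and 20 mL.min-1.g-1.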

Compound 3, intrinsic clearance in microsomes: < 7 mL.min-1.g-1
Compound 3: only a limit was reported; the forecaster's own chance of this, stated with the estimate: 5%; middle value at least 1.2-fold (0.10 log units) away from the limit.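

Compound 3 has a limit of the assay rather than a number, so its steps are floors, and the comparison rests on that limit: the limit of < 7 mL.min-1.g-1 in this assay, at which 1 of the 3 values shown sits.
Aminomethyl in place of (oxan-4-yl)amino gives an at least 1.4-fold lower number from compound 1 to compound 3 (0.15 log units; that floor lies within the scatter), so this change alone does not yet separate the two compounds, although the true gap may be larger. Among these compounds, the change at the same chain to 3-aminopropyl in place of 4-hydroxypiperidin-4-yl gives an at least 2.2-fold lower number from compound 2 to compound 3 (0.35 log units; beyond the scatter), the only step here beyond the scatter, showing that the group at this position can move the number in this assay towards slower removal.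

From the compounds shown here alone, how far the true value of compound 3 lies past its limit remains open. Also open, going by these compounds, is how a dimethylamino group at the end of the same chain, or a longer chain such as 5-aminopentyl, would read in this assay.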